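The source may hold more compounds than are shown below. What is called first, only, known or untested is meant among the compounds shown, and "the series" means these compounds.

In a physicochemical assay for lipophilicity, using the shake flask method, at pH 7.4 (on this read-out lower numbers stand for lower lipophilicity and higher numbers for higher lipophilicity), compound 1 `CCCC(Oc1ccc(-n2cc3ccccc3n2)cc1)c1ccc(C(=O)NCCC(=O)O)cc1` gives 2.5. Compound 2 `O=C(O)CCNC(=O)c1ccc(C(Oc2ccc(-n3cc(C(F)(F)F)cn3)cc2)C2CCC2)cc1` gives 2.6, and compound 3 `CCCC(Nc1cc(C)c(-n2cc(C(F)(F)F)cn2)c(C)c1)c1ccc(C(=O)NCCC(=O)O)cc1` gives 2.2. Compound 1 therefore stands within the scatter of both other compounds. Compound 4 `CCCC(Oc1ccc(-n2cccn2)cc1)c1ccc(C(=O)NCCC(=O)O)cc1` has not yet been measured. It differs from compound 1 in one place, with 1H-pyrazol-1-yl in place of 2H-indazol-2-yl on an aromatic carbon, para to a large group (1H-pyrazol-1-yl in place of 2H-indazol-2-yl on an aromatic carbon). Going by the values given here, no measured pair shows this exchange, so the data give no direct size for it. A downward step beyond the scatter is nevertheless expected in this assay. The expected size is a number 0.70 log units lower from compound 1 to compound 4 (beyond the scatter). Compound 4 is estimated at 1.8, within an expected range of 1.3 to 2.3.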

Compound 4, distribution coefficient: 1.7
Compound 4: the middle estimate sits 0.10 log units above what was measured; low and high end bracket the measured number.
By their numbers in this assay, from the lowest: compound 4; then compounds 3, 1 and 2 (each within the scatter of the next, the first and the last beyond it).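

Exchanging 2H-indazol-2-yl for 1H-pyrazol-1-yl on an aromatic carbon, para to a large group, gives in this assay the first step read at this position: a number 0.80 log units lower from compound 1 to compound 4 (beyond the scatter). The entering group keeps the five-membered aromatic ring with 2 hetero atoms but lacks the six-membered aromatic ring of carbon only, going from 9 to 5 heavy atoms. Nothing measured here accounts for the size of this step.

As far as these compounds go, what an amine or a nitrile on the 1H-pyrazol-1-yl group would give in this assay remains open. So does whether the same exchange gives a similar step with a cyclobutyl group in place of the propyl chain.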